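Alkoxy chain variation on the shared core: ethoxy analogue

This account rests on a few compounds, and the source may have more. Where it says the series, first, only, none or still open, it means among the compounds named here.

Measured compounds:
Compound 1 `CCCOc1ccccc1C1CC(=O)c2ccccc2O1` gives 43.6% in a functional assay on J774.A1 cells (Mus musculus) for inhibition, read by immunoassay, with a stated time of 12 h, tested at 30 uM; a lower number here means less inhibition, a higher number more inhibition at the concentration tested (going by the name of the read-out).
Compound 2 `C=CCOc1ccccc1C1CC(=O)c2ccccc2O1` gives 47% in this assay.
Compound 3 `CCCCOc1ccccc1C1CC(=O)c2ccccc2O1` gives 42.5% in this assay.

Compound 2 holds the highest of the three numbers, but its nearest neighbour is compound 1 and its furthest is compound 3, and both gaps stay within the scatter, so no ordering among the three can be claimed. The next compound, compound 4 `CCOc1ccccc1C1CC(=O)c2ccccc2O1`, differs from compound 2 as follows: methyl in place of vinyl on a saturated chain carbon bound to an oxygen on an aromatic ring.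

Among the compounds with values here, three steps bear on this change, all at the same place on the chain bound to the oxygen on the aromatic ring. The step of a number 3.4 percentage points higher from compound 1 to compound 2 (within the scatter), the step of a number 4.5 percentage points lower from compound 2 to compound 3 (within the scatter) and the step of a number 1.1 percentage points lower from compound 1 to compound 3 (within the scatter) all remained within the scatter. The chain lengths sampled so far thus give no sign that the size or saturation of this group shifts the read-out. Because a number 4.5 percentage points lower from compound 2 to compound 3 (within the scatter) and a number 3.4 percentage points higher from compound 1 to compound 2 (within the scatter) are both within the scatter, the expected step of a number 3 percentage points lower from compound 2 to compound 4 (within the scatter) is also one that should not reach beyond the scatter. Compound 4 is therefore estimated at 44%, with a range from 32% to 56%.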

Compound 4, a percentage reported as inhibition, at one concentration (the size of the read-out at that concentration, not a potency): 27.7%
The estimate for compound 4 lay 16.3 percentage points above the measured number; measured number below the stated range.
By their numbers in this assay, from the lowest: compound 4; then compounds 3, 1 and 2 (each within the scatter of the next).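

Within this assay the ethoxy analogue is the first change at this place, on a saturated chain carbon bound to an oxygen on an aromatic ring, to move the read-out beyond the scatter: the allyl to ethyl change gives a number 19.3 percentage points lower from compound 2 to compound 4 (beyond the scatter) and removal of one chain carbon gives a number 15.9 percentage points lower from compound 1 to compound 4 (beyond the scatter) while removal of two gives a number 14.8 percentage points lower from compound 3 to compound 4 (beyond the scatter) on the same core. Since compounds 1, 2 and 3 stay within the scatter of one another, the four compounds show a separate low position for the ethoxy chain rather than a graded trend with chain length, and the double bond of the allyl group is not needed for the higher numbers, as the saturated chains of compound 1 and compound 3 show. Nothing at hand bears on why the read-out is lower for the ethoxy chain.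

Open, on these data alone, is whether a methoxy group or a bare hydroxyl at this oxygen would lie lower still, and whether a hexyloxy chain would hold the level of the longer chains. Also open, as far as these compounds go, is whether a terminal amine or carboxylic acid on the chain would keep that level, and all of these numbers are sizes at one concentration, not potencies.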